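A few compounds are considered here, and "the series" means these few. Any claim that something is new, unique, unknown or untested is made for them only; others in the source may bear on it.

In this assay, a functional assay on CCRF-CEM cells (Homo sapiens) for antiproliferative activity, with a stated time of 72 h (a higher number here means a weaker inhibitor, a lower number a stronger inhibitor), three compounds that share one core have been measured. Compound 1 `C#CCSc1cnc2ccccc2c1[Se]CC#CCCl` gives 1.8 ug/mL. Compound 2 `CSc1cnc2ccccc2c1[Se]CC#CCCl` gives 1.7 ug/mL, and compound 3 `OCC#CCSc1cnc2ccccc2c1[Se]CC#CCCl` gives 2.6 ug/mL. Compound 1 stands second highest of the three numbers; its nearest neighbour is compound 2, with a 1.1-fold lower number from compound 1 to compound 2 (0.02 log units; within the scatter), and its furthest is compound 3, with a 1.4-fold higher number from compound 1 to compound 3 (0.16 log units; within the scatter). The remaining step, a 1.5-fold higher number from compound 2 to compound 3 (0.18 log units; within the scatter), also lies within the scatter, so the three measured numbers cannot be told apart.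

Compound 4 `C#CCSc1cnc2ccccc2c1SCC#CCCl` has not yet been measured. It differs from compound 1 in one place: a group of 6 heavy atoms (4 carbon, 1 sulfur, 1 chlorine; no ring) in place of a group of 6 heavy atoms (4 carbon, 1 chlorine, 1 selenium; no ring), on an aromatic carbon. The leaving group carries selenium and the entering group carries sulfur, while the chlorine and the triple bond are kept.

Among the compounds with values here, none of the measured steps bears directly on this change. All three of them alter the propargylsulfanyl side of the core and leave the selenium-bearing group untouched, and each of them stayed within the scatter. Within the data shown here, there is therefore no measured guide to the size or direction of the step from compound 1 to compound 4, and the expectation rests on the narrow spread of the three known numbers.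

For compound 4 the estimated step is a 1.4-fold higher number from compound 1 to compound 4 (0.14 log units; within the scatter), expected to stay within the scatter. Compound 4 is estimated at 2.5 ug/mL, with a range from 0.9 ug/mL to 7 ug/mL.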

Compound 4, concentration for 50% inhibition: 2.9 ug/mL
Compound 4: the middle estimate sits 1.2-fold (0.06 log units) below what was measured; the range from low to high includes it.
By their numbers in this assay, from the lowest: compounds 2, 1, 3 and 4 (each within the scatter of the next).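

Within the data shown here, until now every step had altered the propargylsulfanyl side of the shared core, so this is the first look at the other group, on the aromatic carbon opposite the ring nitrogen, where in this assay exchanging selenium for sulfur gives a 1.6-fold higher number from compound 1 to compound 4 (0.21 log units; within the scatter) as the measured result. For this one pair, then, selenium can give way to sulfur, with the chlorine and the triple bond kept, without a difference that this measurement can resolve, so the selenium atom is not required for activity in this range. No accompanying data bear on the result, so it comes with no explanation.

Whether the same exchange stays as small when the other side carries the methyl group of compound 2 or the hydroxymethyl-bearing chain of compound 3 remains open, since only the pair with the propargylsulfanyl group is shown. Also open, as far as these compounds go, is how much the chlorine-bearing chain itself contributes, which an amine in place of the chlorine, a longer chain, or an oxygen atom in place of the sulfur or selenium link would help to show.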